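Trimming the propyl of compound 1 to methyl

A few compounds are considered here, and "the series" means these few. Any claim that something is new, unique, unknown or untested is made for them only; others in the source may bear on it.

Compound 1, `CCCc1cc(-c2cn([C@H]3C[C@H](OC(C)=O)[C@@H](COC(C)=O)O3)c(=O)[nH]c2=O)on1`, is the reference point of this set. In a functional assay on ACHN cells (Homo sapiens) for cytotoxicity, read by sulforhodamine B assay, tested at 10 uM (a higher number here means more inhibition at the concentration tested (going by the name of the read-out), a lower number less inhibition), compound 1 gives 99.5%, the top figure among the three measured compounds, though the gaps to the other two both lie within the scatter. Compound 2, `CC(=O)OC[C@H]1O[C@@H](n2cc(-c3cc(-c4ccccc4)no3)c(=O)[nH]c2=O)C[C@@H]1OC(C)=O`, gives 97.6% in this assay, and compound 3, `CC(C)(C)c1ccc(-c2cc(-c3cn([C@H]4C[C@H](O)[C@@H](CO)O4)c(=O)[nH]c3=O)on2)cc1`, gives 94.2%; compound 3 differs from compound 1 in more than one place, so its value serves only as a second point near the top of the range.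

Among the measured compounds shown here, the single clean step in the set is a number 1.9 percentage points lower from compound 1 to compound 2 (within the scatter), a change at the same position that is now varied further. Compound 4, `CC(=O)OC[C@H]1O[C@@H](n2cc(-c3cc(C)no3)c(=O)[nH]c2=O)C[C@@H]1OC(C)=O`, differs from compound 1 by hydrogen in place of ethyl on a saturated chain carbon bound to an aromatic carbon. For the measured compounds named here, only the step from compound 1 to compound 2 bears on this change, and it stayed within the scatter, so no step beyond the scatter is expected here either. The shortening of the chain is expected to leave compound 4 near the top of the range, with an estimated change of a number 3.5 percentage points lower from compound 1 to compound 4 (within the scatter). Compound 4 is accordingly estimated at 96%, within a range from 87% to 100%.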

Compound 4, a percentage reported as inhibition, at one concentration (the size of the read-out at that concentration, not a potency): 96.4%
Compound 4: middle estimate off by 0.4 percentage points, on the low side; the measured number falls inside the stated range.
By their numbers in this assay, from the lowest: compounds 3, 4, 2 and 1 (each within the scatter of the next).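

In this assay, the cut from propyl to methyl gives a number 3.1 percentage points lower from compound 1 to compound 4 (within the scatter), and methyl in place of phenyl on the same aromatic carbon gives a number 1.2 percentage points lower from compound 2 to compound 4 (within the scatter). The earlier compounds shown here offered only the pairing of propyl with phenyl; with methyl added, the shortest of the three groups also stays in the same narrow band near the top of the range, so none of the three substituents on this carbon can be separated from the others at the concentration tested. No measurement available here gives a reason for this flat response at the position, and none links it to any property of the three groups.

With all the values this close to the top of the read-out, a single concentration cannot show whether real differences between propyl, phenyl and methyl exist, so graded concentrations would be needed to rank them. As far as these compounds go, it also remains open whether an amine, a carboxylic acid or a longer chain such as octyl on this carbon would keep the number in this band, and how far the acetate esters contribute, given that compound 3 differs from compound 1 in more than one place.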